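The source may hold more compounds than are shown below. What is called first, only, known or untested is meant among the compounds shown, and "the series" means these compounds.

Compound 1 `COc1ccc(/C=C2\CCC/C(=C\c3cc(OC)c(OC)c(OC)c3)C2=O)cc1OC`: 1300 nM
Compound 2 `COc1cc(/C=C2\CCC/C(=C\c3ccccc3F)C2=O)cc(OC)c1OC`: 1500 nM
Compound 3 `COc1cc(/C=C2\CCC/C(=C\c3cccc(O)c3)C2=O)cc(OC)c1OC`: 6500 nM

These three compounds share one core and differ only in the aromatic group on a double-bonded chain carbon bound to a double-bonded ring carbon. In a functional assay on RKO cells (Homo sapiens) for antiproliferative activity, read by MTT assay, with a stated time of 72 h (on this read-out lower numbers stand for stronger inhibition and higher numbers for weaker inhibition), compound 3 gives the highest number of the three, so it is the weakest inhibitor: the step of a 5.0-fold higher number from compound 1 to compound 3 (0.70 log units; beyond the scatter) and the step of a 4.3-fold higher number from compound 2 to compound 3 (0.64 log units; beyond the scatter) both lie beyond the scatter, while the step of a 1.2-fold higher number from compound 1 to compound 2 (0.06 log units; within the scatter) does not.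

Compound 4 `COc1cc(/C=C2\CCC/C(=C\c3ccc(F)c(F)c3)C2=O)cc(OC)c1OC` is the next compound, and it differs from compound 3 as follows: 3,4-difluorophenyl in place of 3-hydroxyphenyl on a double-bonded chain carbon bound to a double-bonded ring carbon.

For the measured compounds named here, two measured steps bear on this change. Both runs in the opposite direction: compound 3 carries the 3-hydroxyphenyl, and leaving it for the 2-fluorophenyl of compound 2 or the 3,4-dimethoxyphenyl of compound 1 corresponds to reversing a 4.3-fold higher number from compound 2 to compound 3 (0.64 log units; beyond the scatter) and a 5.0-fold higher number from compound 1 to compound 3 (0.70 log units; beyond the scatter). Compound 4 swaps the 3-hydroxyphenyl for a 3,4-difluorophenyl, which resembles those two groups in lacking the hydroxyl. A modest fall in the number, roughly matching those steps, is therefore expected for compound 4, with the exact size uncertain. The expected step is a 4.3-fold lower number from compound 3 to compound 4 (0.64 log units; beyond the scatter). Compound 4 is estimated at 1500 nM, with a range from 600 nM to 4000 nM.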

Compound 4, half-maximal inhibitory concentration: 2200 nM
For compound 4 the middle estimate is 1.5-fold (0.17 log units) below the measured one, and the stated range covers the measured number.
By their numbers in this assay, from the lowest: compounds 1, 2 and 4 (each within the scatter of the next); then compound 3.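

In this assay the step of a 3.0-fold lower number from compound 3 to compound 4 (0.47 log units; beyond the scatter) shows that the fall in the number seen on leaving the 3-hydroxyphenyl is not confined to the 2-fluorophenyl and the 3,4-dimethoxyphenyl: a third group without a hydroxyl, the 3,4-difluorophenyl, also gives it. For the compounds shown here, the steps of a 1.5-fold higher number from compound 2 to compound 4 (0.17 log units; within the scatter) and a 1.7-fold higher number from compound 1 to compound 4 (0.23 log units; within the scatter) both lie within the scatter, so these three hydroxyl-free groups cannot be told apart here, although two of them carry fluorine and one carries methoxy groups, and among the four compounds only compound 3, the one with a hydrogen-bond donor on this aromatic group, stands apart, with no compound going against this. Nothing among the data shown accounts for why the 3-hydroxyphenyl stands apart.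

What remains open is whether this gap belongs to the hydroxyl itself, since the compounds shown do not include a methoxy group or an amine in its place on the same ring. They also leave open how a carboxylic acid on that ring would fare at this position.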